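This account rests on a few compounds, and the source may have more. Where it says the series, first, only, none or still open, it means among the compounds named here.

Working notes on the series. All three measured compounds share one core and differ only in the group on the carbon with a double bond to nitrogen. Compound 1 `O=C(COc1cccc2ccccc12)N/N=C/c1ccccc1Br` carries 2-bromophenyl there; in an ADME assay on MT4 cells (Homo sapiens) for cytotoxicity, read by MTT assay, with a stated time of 4 days (a lower number here means that less compound is tolerated, a higher number that more compound is tolerated), compound 1 gives 11.4 ug/mL. Compound 2 `Cc1ccc(/C=N/NC(=O)COc2cccc3ccccc23)cc1` carries 4-methylphenyl, and in this assay compound 2 gives 83.9 ug/mL. Compound 3 `O=C(COc1cccc2ccccc12)N/N=C/c1ccccc1Cl` carries 2-chlorophenyl, and in this assay compound 3 gives 56.2 ug/mL, the second highest of the three numbers: the step of a 1.5-fold lower number from compound 2 to compound 3 (0.17 log units; within the scatter) is within the scatter, while a 4.9-fold higher number from compound 1 to compound 3 (0.69 log units; beyond the scatter) and a 7.4-fold higher number from compound 1 to compound 2 (0.87 log units; beyond the scatter) are modest steps beyond it.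

Among the compounds with values here, compound 4 `O=C(COc1cccc2ccccc12)N/N=C/C=C/c1ccccc1` is not yet measured. 2-phenylethenyl in place of 2-chlorophenyl on a carbon with a double bond to nitrogen No measured step exchanges an aryl group for 2-phenylethenyl at this position, so none bears on the change directly; the measured steps show only that changes at this position move the number by modest amounts at most. The step of a 1.2-fold lower number from compound 3 to compound 4 (0.10 log units; within the scatter) is therefore expected to be small and uncertain in direction. Compound 4 is estimated at 45 ug/mL in this assay, with a range of 15 ug/mL to 120 ug/mL.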

Compound 4, half-maximal cytotoxic concentration: 82.7 ug/mL
Estimate against measurement, compound 4: 1.8-fold (0.26 log units) below, within the range that was stated.
By their numbers in this assay, from the lowest: compound 1; then compounds 3, 4 and 2 (each within the scatter of the next).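

In this assay, the exchange of an aryl group for 2-phenylethenyl on a carbon with a double bond to nitrogen can now be read directly, and both a 1.5-fold higher number from compound 3 to compound 4 (0.17 log units; within the scatter) and a 1.0-fold lower number from compound 2 to compound 4 (0.01 log units; within the scatter) stay within the scatter. Only a 7.3-fold higher number from compound 1 to compound 4 (0.86 log units; beyond the scatter) lies beyond it, so among the four compounds compound 1, with 2-bromophenyl, alone stands apart, while the added double bond outside aromatic rings does not separate compound 4 from compounds 2 and 3. No measurement at hand explains any of these numbers.

Still open, going by these compounds, is whether the low number is specific to 2-bromophenyl or would also appear with 2-iodophenyl. Also open, on these data alone, is how a longer chain with further double bonds, an amine on the phenyl ring or a change in the shared core would read here.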